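This account rests on a few compounds, and the source may have more. Where it says the series, first, only, none or still open, it means among the compounds named here.

Compound 1 `Cc1cc(=O)n(-c2ccccc2C(F)(F)F)nc1C(=O)Nc1ccc(Oc2ncnc3ccsc23)cc1`: 8850 nM
Compound 2 `Cc1cc(=O)n(-c2ccccc2C(F)(F)F)nc1C(=O)Nc1ccc(Oc2ncnc3sccc23)cc1`: 19900 nM

In a functional assay on A549 cells (Homo sapiens) for cytotoxicity, read by MTT assay, with a stated time of 72 h (on this read-out lower numbers stand for stronger inhibition and higher numbers for weaker inhibition), compound 2 stands at the higher of the two numbers; its nearest neighbour is compound 1, and the two are separated by a 2.2-fold higher number from compound 1 to compound 2 (0.35 log units; beyond the scatter). Compound 3 `Cc1cc(=O)n(-c2cccc(F)c2)nc1C(=O)Nc1ccc(Oc2ncnc3sccc23)cc1` differs from compound 2 at another part of the molecule: 3-fluorophenyl in place of 2-(trifluoromethyl)phenyl on an aromatic nitrogen. Going by the values given here, none of the measured steps touches this position. Among the compounds with values here, the one step known, a 2.2-fold higher number from compound 1 to compound 2 (0.35 log units; beyond the scatter), concerns the ring system on the ether oxygen, not the aryl group on the aromatic nitrogen of the shared core, so it offers no guide to the size or direction of the present change. With no bearing data, the expected step in this assay is a 1.0-fold higher number from compound 2 to compound 3 (0.00 log units; within the scatter), that is, nothing beyond the scatter, though the uncertainty is wide. Compound 3 is therefore estimated at 20000 nM, with a range from 6000 nM to 70000 nM.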

Compound 3, half-maximal inhibitory concentration: 16400 nM
Estimate against measurement, compound 3: 1.2-fold (0.09 log units) above; the measured number falls inside the stated range.
By their numbers in this assay, from the lowest: compounds 1, 3 and 2 (each within the scatter of the next, the first and the last beyond it).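

In this assay, the exchange of 2-(trifluoromethyl)phenyl for 3-fluorophenyl on the aromatic nitrogen gives a 1.2-fold lower number from compound 2 to compound 3 (0.08 log units; within the scatter). Going by these compounds alone, this is the first reading at this position, and it shows that the aryl group can go from 10 heavy atoms to 7, with a single fluorine in place of trifluoromethyl, without a difference that stands clear of the scatter in this pair. No measurement at hand offers an explanation for this result.

As far as these compounds go, it remains open whether any aryl group at this position would give the same reading, for instance one carrying an amine or a carboxylic acid, or a plain methyl in place of the ring. From the compounds shown here alone, it is also open whether 3-fluorophenyl would behave the same way with the ether-linked ring system of compound 1.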